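This account rests on a few compounds, and the source may have more. Where it says the series, first, only, none or still open, it means among the compounds named here.

Measured compounds:
- compound 1, `C[C@H](NC(=O)c1nnn(Cc2ccc(F)cc2)c1C(F)(F)F)c1ccc(C(=O)O)cc1`, in a functional assay on CHO cells for antagonist activity at prostaglandin E2 receptor EP4 subtype (Homo sapiens), read by calcium flux, with a stated time of 15 min (a higher number here means a weaker inhibitor, a lower number a stronger inhibitor), gives > 10000 nM
- compound 2, `C[C@H](NC(=O)c1cn(Cc2ccc(C(F)(F)F)cc2)nn1)c1ccc(C(=O)O)cc1`, in this assay gives > 10000 nM

The value recorded for compound 2 is a limit of this assay, not a number. The value for compound 1 is a limit as well. Thus, of the two values shown, both sit at the limit of > 10000 nM in this assay, at which 2 of the 2 values shown sit, and compound 2 can be placed no more exactly than that.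

Compound 3, `CCc1c(C(=O)N[C@@H](C)c2ccc(C(=O)O)cc2)nnn1Cc1ccc(C(F)(F)F)cc1`, differs from compound 2 in one place: ethyl in place of hydrogen on an aromatic carbon of the five-membered aromatic ring with three nitrogen. No step between measured compounds is shown, so nothing measured tells which way this change moves the read-out. The step from compound 2 to compound 3 is expected to be a step that the limit leaves unreadable from compound 2 to compound 3, with no direction beyond the scatter. Compound 3 is therefore expected to give about 15000 nM, within 3000 nM to 60000 nM, most likely reported as a limit again.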

Compound 3, half-maximal inhibitory concentration: > 10000 nM
Compound 3 ended at the assay's limit; the forecaster's own chance of this, stated with the estimate: 75%; the middle value is on the limit's open side.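

Compound 3 gives a limit of this assay and not a number, as compound 2 does, so no step can be read between the two: the limit of > 10000 nM in this assay, at which 3 of the 3 values shown sit. The compounds shown leave open whether ethyl in place of hydrogen changes the read-out at all, and what on the shared core would give a measurable value.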